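This account rests on a few compounds, and the source may have more. Where it says the series, first, only, none or still open, it means among the compounds named here.

Working notes on the series. For the measured compounds named here, in a functional assay on HT-29 cells (Homo sapiens) for inhibition, read by MTT assay (a lower number here means a stronger inhibitor of growth, a higher number a weaker inhibitor of growth), compound 1 `O=c1c(-c2ccc(OC(F)F)cc2)coc2cc(OC(F)F)cc(O)c12` gives 5.35 uM, the lower of the two numbers so far; compound 2 `CCCCCCCCCCOc1ccc(-c2coc3cc(OCCCCCCCCCC)cc(O)c3c2=O)cc1` gives 11.6 uM, a higher number, beyond the usual scatter. Compound 3 `O=c1c(-c2ccc(O)cc2)coc2cc(OC(F)F)cc(O)c12` is not yet measured. It differs from compound 1 in one place: hydrogen in place of difluoromethyl on an oxygen on an aromatic ring. Going by the values given here, no measured pair shows this change, so the size of the step is open. The step from compound 1 to compound 3 in this assay is expected to be small, perhaps a slightly higher number, a 1.7-fold higher number from compound 1 to compound 3 (0.23 log units; within the scatter). For compound 3 the value is estimated at 9 uM, within 3 uM to 30 uM.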

Compound 3, concentration for growth inhibition (reported as GI): 4.56 uM
For compound 3 the middle estimate is 2.0-fold (0.30 log units) above the measured one; the range from low to high includes it.
By their numbers in this assay, from the lowest: compounds 3 and 1 (each within the scatter of the next); then compound 2.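

In this assay, for the compounds shown here, the first single-place pair gives a 1.2-fold lower number from compound 1 to compound 3 (0.07 log units; within the scatter). Difluoromethoxy to hydroxy at this place therefore leaves compound 1 and compound 3 indistinguishable in growth inhibition, so the difluoromethyl on this oxygen is not needed to keep that level in this pair. Nothing available bears on why the step is this size.

Going by these compounds, the effect of a methyl or an aminoethyl group on this same oxygen remains open. So does the step for changing the other difluoromethoxy group, shared by compound 1 and compound 3.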